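From compound 2 to compound 4: methyl becomes ethyl

A few compounds are considered here, and "the series" means these few. Any claim that something is new, unique, unknown or untested is made for them only; others in the source may bear on it.

Measured in a physicochemical assay for solubility, measured as octanol-water partition, at pH 5.5; on this read-out higher numbers stand for higher solubility and lower numbers for lower solubility:
- compound 1 `Nc1cc(OCCNc2ccnc3cc(Cl)ccc23)nc(N)n1`: 150 nM
- compound 2 `CC(COc1cc(N)nc(N)n1)Nc1ccnc2cc(Cl)ccc12`: 70 nM
- compound 3 `Nc1cc(OCCOCCNc2ccnc3cc(Cl)ccc23)nc(N)n1`: 600 nM

Compound 2 has the lowest number of these three, and compound 1 and compound 3 both stand above it by more than the usual scatter. Compound 4 `CCC(COc1cc(N)nc(N)n1)Nc1ccnc2cc(Cl)ccc12` has not been measured yet. The change that leads to it from compound 2 is methyl in place of hydrogen on a saturated chain carbon, two bonds along the chain from a nitrogen on an aromatic ring. Read one bond further out, this is methyl to ethyl.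

Among the compounds with values here, only one measured step resembles this change: a 2.1-fold lower number from compound 1 to compound 2 (0.33 log units; beyond the scatter). That modest step also put a methyl in place of hydrogen on a saturated chain carbon, but on the carbon bound to the nitrogen, not the one changing now. Within the data shown here, no measured step links compound 3 to this change, and a single step is thin evidence. In this assay, a move in the same direction, towards a lower number, is therefore expected, though smaller and perhaps lost in the scatter. The expected step is a 1.4-fold lower number from compound 2 to compound 4 (0.15 log units; within the scatter). For compound 4 the estimated value is 50 nM, with an expected range of 20 nM to 120 nM.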

Compound 4, solubility: 490 nM
Compound 4: the middle estimate sits 9.8-fold (0.99 log units) below what was measured; the whole stated range lies below it.
By their numbers in this assay, from the lowest: compound 2; then compound 1; then compounds 4 and 3 (each within the scatter of the next).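

In this assay, extending methyl to ethyl at this place gives a 7.0-fold higher number from compound 2 to compound 4 (0.85 log units; beyond the scatter), which runs opposite to the earlier methyl-for-hydrogen change on the neighbouring chain carbon, a 2.1-fold lower number from compound 1 to compound 2 (0.33 log units; beyond the scatter). Set against the chain with only hydrogen there, the ethyl-bearing carbon gives a 3.3-fold higher number from compound 1 to compound 4 (0.51 log units; beyond the scatter), so methyl and ethyl on the chain carbon bound to the nitrogen on an aromatic ring move the number in opposite directions relative to hydrogen. The direction of the earlier methyl step therefore did not carry over to this change, and the series hydrogen, methyl, ethyl does not follow a steady trend, though no information here accounts for this reversal.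

The compounds shown leave open whether a longer chain such as propyl, or a branched group such as isopropyl, would continue this rise or reverse it again. They also leave open how a group with a heteroatom at this place, such as a hydroxyl or an amine, would compare with ethyl, and whether the same ethyl would give a similar step on the longer chain of compound 3.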